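Tert-butyl added to the phenyl of compound 3

This account rests on a few compounds, and the source may have more. Where it says the series, first, only, none or still open, it means among the compounds named here.

Compound 1, `O=C1NC(O)(CCn2cc(C3=CCCCC3)nn2)C(OCc2ccccc2)=C1OCc1ccccc1`: 70000 nM
Compound 2, `CC(C)(C)c1ccc(-c2cn(C/C=C3\OC(=O)C(OCc4ccccc4)=C3OCc3ccccc3)nn2)cc1`: > 100000 nM, a limit
Compound 3, `O=C1NC(O)(CCn2cc(-c3ccccc3)nn2)C(OCc2ccccc2)=C1OCc1ccccc1`: > 100000 nM, a limit

In an ADME assay on HEK293 cells (Homo sapiens) for cytotoxicity, read by MTT assay, with a stated time of 24 h (a higher number here means a weaker inhibitor, a lower number a stronger inhibitor), compound 3 returns only a limit, not a number. Compound 2 sits at the same limit (the limit of > 100000 nM in this assay, at which 2 of the 3 values shown sit), so compound 1 alone gives a measured number. Among the compounds with values here, the one measured step, an at least 1.4-fold higher number from compound 1 to compound 3 (0.15 log units; that floor lies within the scatter), carries a floor that lies within the scatter. Compound 4, `CC(C)(C)c1ccc(-c2cn(CCC3(O)NC(=O)C(OCc4ccccc4)=C3OCc3ccccc3)nn2)cc1`, differs from compound 3 by tert-butyl in place of hydrogen on an aromatic carbon. Within the data shown here, no measured step adds this group to a compound with a number, and compound 2, which carries the same group on a different core, also shows only a limit. For compound 4 the step that the limit leaves unreadable from compound 3 to compound 4 is therefore expected to be none beyond the scatter. The estimate for compound 4 is 150000 nM, with a range from 60000 nM to 400000 nM.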

Compound 4, half-maximal inhibitory concentration: > 100000 nM
Compound 4: a limit, no number (the forecaster's own chance of this, stated with the estimate: 80%); the middle value is on the limit's open side.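

In this assay, the position on the phenyl takes a tert-butyl group and compound 4 still returns only a limit, so this change yields no number here. Within the data shown here, the step between compound 3 and compound 4 cannot be read, and the one readable step, an at least 1.4-fold higher number from compound 1 to compound 4 (0.15 log units; that floor lies within the scatter), gives only a floor. The values now gather further at one limit: the limit of > 100000 nM in this assay, at which 3 of the 4 values shown sit.

Going by these compounds, how far compound 3 and compound 4 lie past that limit stays open. So does whether an amine or a carboxylic acid in place of the tert-butyl would give a measured number.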